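Chain extension on the aryl ether: three measured, one pending

The compounds below may be only part of what the source reports. "The series", "measured", "known", "first", "only" and "open" are said of these compounds alone.

Measured compounds:
compound 1, `CCCCOc1ccc2c(Cl)ccnc2c1`, gives 3050 nM
compound 2, `CCCCCCCCOc1ccc2c(Cl)ccnc2c1`, gives 3640 nM
compound 3, `CCOc1ccc2c(NCCN(C)C)ccnc2c1`, gives 3650 nM

All three were read in a functional assay on RKO cells (Homo sapiens) for cytotoxicity, read by MTT assay, with a stated time of 48 h; a higher number here means a weaker inhibitor, a lower number a stronger inhibitor. Compound 1 and compound 2 share a core and differ by butyl in place of hydrogen on a saturated chain carbon, four bonds along the chain from an oxygen on an aromatic ring; this change produced a 1.2-fold higher number from compound 1 to compound 2 (0.08 log units; within the scatter). Compound 3 carries a different core, and the difference between the two cores is not broken down here; its value in this assay sits close to those of compound 1 and compound 2, all within the scatter of one another.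

Compound 4, `CCCCCCOc1ccc2c(NCCN(C)C)ccnc2c1`, is not yet measured. It differs from compound 3 by butyl in place of hydrogen on a saturated chain carbon, two bonds along the chain from an oxygen on an aromatic ring. This is the same kind of change as that from compound 1 to compound 2, but not the same: there the butyl enters four bonds along the chain from the oxygen, here two bonds along. On the core of compound 3 the step is expected to be a 1.1-fold higher number from compound 3 to compound 4 (0.04 log units; within the scatter), resting on the earlier 1.2-fold higher number from compound 1 to compound 2 (0.08 log units; within the scatter), with added uncertainty from the different core. Compound 4 is therefore estimated at 4000 nM, between 2000 nM and 8500 nM.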

Compound 4, half-maximal inhibitory concentration: 1120 nM
Estimate against measurement, compound 4: 3.6-fold (0.55 log units) above; measured number outside the range, below it.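

In this assay the butyl change on the core of compound 3 gives a 3.3-fold lower number from compound 3 to compound 4 (0.51 log units; beyond the scatter) and does not repeat the earlier step on the core of compound 1, as the two steps differ: the same change on two cores in this assay, a 1.2-fold higher number (0.08 log units; within the scatter) from compound 1 to compound 2 and a 3.3-fold lower number (0.51 log units; beyond the scatter) from compound 3 to compound 4, 3.9-fold (0.59 log units) apart, beyond the scatter of two such steps

The size of the step therefore cannot be carried from one core to the other in this series, and an ethoxy to hexyloxy change on the core of compound 3 has to be read on its own. This does not show that the core alone sets the outcome, since the butyl enters four bonds along the chain in one pair and two bonds along in the other, and a single pair on each core cannot separate these two differences.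

Open, as far as these compounds go, is whether a longer chain, such as decyl, on the core of compound 3 would extend the step or reverse it. Also open, from the compounds shown here alone, is how the hexyloxy chain would behave with a morpholine in place of the dimethylamine.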